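This account rests on a few compounds, and the source may have more. Where it says the series, first, only, none or still open, it means among the compounds named here.

Series notes, read in a functional assay on A2780 cells (Homo sapiens) for inhibition, with a stated time of 72 h; on this read-out higher numbers stand for weaker inhibition and lower numbers for stronger inhibition:

- compound 1 `CC(=O)O[C@@]1([C@@H]2/C(C)=C(/O)C(=O)C3=C(C)[C@@H](OC(=O)[C@H](O)[C@H](C=C(C)C)NC(=O)OC(C)(C)C)C[C@@](O)([C@H]2OC(=O)c2cccc(Cl)c2)C3(C)C)CO[C@@H]1CCO`: 452 nM
- compound 2 `CC(=O)O[C@@]1([C@@H]2/C(C)=C(/O)C(=O)C3=C(C)[C@@H](OC(=O)[C@H](O)[C@H](CC(C)C)NC(=O)OC(C)(C)C)C[C@@](O)([C@H]2OC(=O)c2cccc(Cl)c2)C3(C)C)CO[C@@H]1CCO`: 604 nM
- compound 3 `COc1cccc(C(=O)O[C@H]2[C@H]([C@]3(OC(C)=O)CO[C@@H]3CCO)/C(C)=C(/O)C(=O)C3=C(C)[C@@H](OC(=O)[C@H](O)[C@H](C=C(C)C)NC(=O)OC(C)(C)C)C[C@]2(O)C3(C)C)c1`: not yet measured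

Compound 1 has a single neighbour on these numbers, and the two lie within the scatter of each other: a 1.3-fold higher number from compound 1 to compound 2 (0.13 log units; within the scatter). No order between them can be read from the data.

Compound 3 keeps the core of compound 1 and alters only the aromatic ring: methoxy in place of chloro on an aromatic carbon. In words, 3-chlorophenyl becomes 3-methoxyphenyl, with methoxy in place of chloro on an aromatic carbon, meta to a large group.

Among the compounds with values here, no measured step touches this ring. Within the data shown here, the one available step, a 1.3-fold higher number from compound 1 to compound 2 (0.13 log units; within the scatter), lies at a different place on the molecule, so it bears only indirectly, as a single change that stayed within the scatter. The data therefore give no direction for the new change, and the range has to stay wide.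

With compound 1 at 452 nM as the anchor, no shift beyond the scatter is expected in this assay. The expected step is a 1.1-fold higher number from compound 1 to compound 3 (0.04 log units; within the scatter). For compound 3 the estimated value is 500 nM, with an expected range of 170 nM to 1500 nM.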

Compound 3, half-maximal inhibitory concentration: 386 nM
Beside the measured number, compound 3's estimate is 1.3-fold (0.11 log units) above it; the measured number falls inside the stated range.
By their numbers in this assay, from the lowest: compounds 3, 1 and 2 (each within the scatter of the next).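

In this assay the aromatic ring now has its first reading, the swap of chloro for methoxy on an aromatic carbon, meta to a large group (a 1.2-fold lower number from compound 1 to compound 3 (0.07 log units; within the scatter)). This step stays within the scatter, so 3-chlorophenyl and 3-methoxyphenyl cannot be told apart on this read-out, even though the entering group brings one more heavy atom and a hydrogen-bond acceptor that chloro lacks. No independent measurement is available to account for this result.

From the compounds shown here alone, two groups at one carbon do not define how much variation this position accepts, so the outcome with an amine, a carboxylic acid, a longer alkoxy chain or a plain unsubstituted phenyl remains open. Going by these compounds, it is also open whether the isobutyl chain of compound 2 and the 3-methoxyphenyl of compound 3 would read the same when carried together on the shared core, and whether this flat picture holds on any cell line other than the one used here.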